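Amine swaps on the shared core: outlook for compound 3

The source may hold more compounds than are shown below. What is called first, only, known or untested is meant among the compounds shown, and "the series" means these compounds.

Compound 1, `Clc1ccc(Nc2nc3c(N4CCCC4)ncnc3s2)cc1`: in a functional assay on CHO-K1 cells for antagonist activity at adenosine receptor A2b (Homo sapiens), read by 33P incorporation, with a stated time of 20 min, in the presence of a further agent that is not named here (a lower number here means a stronger inhibitor, a higher number a weaker inhibitor), compound 1 gives > 10000 nM, a limit of the assay.
Compound 2, `OC[C@@H]1CCCN1c1ncnc2sc(Nc3ccc(Cl)cc3)nc12`: in this assay compound 2 gives > 10000 nM, a limit of the assay.

Compound 2 stands only at a limit, so the step that the two limits leave unreadable from compound 1 to compound 2 has no readable size, because of the limit of > 10000 nM in this assay, at which 2 of the 2 values shown sit. Compound 3, `CN(C)c1ncnc2sc(Nc3ccc(Cl)cc3)nc12`, differs from compound 2 by dimethylamino in place of 2-(hydroxymethyl)pyrrolidin-1-yl on an aromatic carbon. For the measured compounds named here, no measured step bears on this change with a readable size; the one step from compound 1 to compound 2 is unreadable. For compound 3 the expectation is therefore a further limit in this assay, with an estimated step that the limit leaves unreadable from compound 2 to compound 3. Compound 3 is estimated at 20000 nM, within 5000 nM to 80000 nM.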

Compound 3, inhibition constant: > 10000 nM
Compound 3: only a limit was reported (the forecaster's own chance of this, stated with the estimate: 85%); the middle value does not contradict the limit.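

In this assay, for the compounds shown here, compound 1, compound 2 and compound 3 all stand at a limit, so no step among them can be read: the limit of > 10000 nM in this assay, at which 3 of the 3 values shown sit.
Which amine on the shared core, if any, gives a readable inhibition constant remains open.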